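This account rests on a few compounds, and the source may have more. Where it says the series, first, only, none or still open, it means among the compounds named here.

Among the measured compounds shown here, in a functional assay on MOLT-4 cells (Homo sapiens) for inhibition (on this read-out lower numbers stand for stronger inhibition and higher numbers for weaker inhibition), compound 2 `O=C1CCCCC/C1=C\c1cccc(F)c1` gives 482000 nM, the only actual number so far. Compound 1 `Cc1ccc(/C=C2\Cc3ccccc3C2=O)cc1` reaches only a limit of the assay, > 500000 nM. Compound 3 `O=C1CCCCC/C1=C\c1cccc([N+](=O)[O-])c1` keeps the core of compound 2 but has nitro in place of fluoro on an aromatic carbon. For the measured compounds named here, no measured step shows what such a swap does in this assay, so only a modest move towards stronger inhibition is expected, and the estimated change is a 2.4-fold lower number from compound 2 to compound 3 (0.38 log units; beyond the scatter). For compound 3 the expected value is 200000 nM, with an estimated range from 40000 nM to 600000 nM.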

Compound 3, half-maximal inhibitory concentration: 39200 nM
For compound 3 the middle estimate is 5.1-fold (0.71 log units) above the measured one; measured number outside the range, below it.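

In this assay, among the compounds shown here, putting nitro in place of fluoro on the aromatic carbon gives a 12-fold lower number from compound 2 to compound 3 (1.09 log units; beyond the scatter), the first measured step in this set, so the group at this position clearly matters for the read-out. Nothing shown here explains why this swap has such a large effect. From the compounds shown here alone, what an amine or a carboxylic acid would do on the same carbon remains open. Also open, going by these compounds, is whether nitro would give a similar step on a different core, such as that of compound 1.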